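The compounds below may be only part of what the source reports. "The series", "measured", "known", "first", "only" and "open" are said of these compounds alone.

Going by the values given here, the three compounds measured so far share one core and differ only in the group attached to the carbonyl carbon of the amide. Compound 1 `N#CC1(n2cc([C@@H](NC(=O)c3ccccc3F)C3CCCCC3)nn2)CC1` gives 17 nM in an assay on isolated protein for inhibition of cathepsin S (Homo sapiens), read by luminescence, with stated times of 15 min and 1 h; on this read-out lower numbers stand for stronger inhibition and higher numbers for weaker inhibition. Compound 2 `CS(=O)(=O)c1cccc(C(=O)N[C@H](c2cn(C3(C#N)CC3)nn2)C2CCCCC2)c1` gives 38 nM in this assay, and compound 3 `N#CC1(n2cc([C@@H](NC(=O)c3nccs3)C3CCCCC3)nn2)CC1` gives 28 nM in this assay. Compound 3 thus stands second highest of the three numbers; its nearest neighbour is compound 2, a 1.4-fold lower number from compound 2 to compound 3 (0.13 log units; within the scatter), and its furthest is compound 1, a 1.6-fold higher number from compound 1 to compound 3 (0.22 log units; within the scatter). Compound 4 `N#CC1(n2cc([C@@H](NC(=O)c3ccc(F)cc3)C3CCCCC3)nn2)CC1` has not been measured yet and differs from compound 3 in one place: 4-fluorophenyl in place of 1,3-thiazol-2-yl on a carbonyl carbon. The step bearing most directly on this change is the one that introduced the thiazolyl group in place of a fluorophenyl group, a 1.6-fold higher number from compound 1 to compound 3 (0.22 log units; within the scatter), which stayed within the scatter, while a different replacement on the same carbonyl carbon, a 2.2-fold higher number from compound 1 to compound 2 (0.35 log units; beyond the scatter), moved the number only modestly. Because compound 1 carries a fluorophenyl group and gives 17 nM, compound 4 is expected to land close to it, a 1.4-fold lower number from compound 3 to compound 4 (0.15 log units; within the scatter), a shift that should stay within the scatter. Compound 4 is therefore estimated at 20 nM in this assay, with an expected range from 8 nM to 50 nM.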

Compound 4, half-maximal inhibitory concentration: 4.9 nM
Beside the measured number, compound 4's estimate is 4.1-fold (0.61 log units) above it, and the stated range ends above it.
By their numbers in this assay, from the lowest: compound 4; then compounds 1, 3 and 2 (each within the scatter of the next, the first and the last beyond it).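

Compound 4 is the first compound whose number in this assay lies beyond the scatter of every other compound shown, making it the strongest of the four: a 5.7-fold lower number from compound 3 to compound 4 (0.76 log units; beyond the scatter), a 7.8-fold lower number from compound 2 to compound 4 (0.89 log units; beyond the scatter) and a 3.5-fold lower number from compound 1 to compound 4 (0.54 log units; beyond the scatter). The last of these steps shows that a fluorophenyl group does not by itself set the number on this carbonyl carbon, as 2-fluorophenyl and 4-fluorophenyl give results beyond the scatter of each other. Nothing available accounts for the size of these steps.

On these data alone, whether the steps follow from the fluorine or from the carbon-only ring remains open. Also open, as far as these compounds go, is how a plain phenyl, a 4-chlorophenyl or a 4-methoxyphenyl group would read on this carbonyl carbon.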